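The source may hold more compounds than are shown below. What is called first, only, known or untested is meant among the compounds shown, and "the series" means these compounds.

In a functional assay on MCF7 cells (Homo sapiens) for inhibition, read by MTT assay (a lower number here means a stronger inhibitor, a higher number a weaker inhibitor), compound 1 `COc1ccccc1N1CCN(CC(=O)Nc2ccc(C(=O)/C=C/c3cn(Cc4ccc(Br)cc4)nn3)cc2)CC1` gives 36800 nM. Going by the values given here, compound 2 `CC(C)(C)OC(=O)N1CCN(CC(=O)Nc2ccc(C(=O)/C=C/c3cn(Cc4ccc(Br)cc4)nn3)cc2)CC1` gives 31000 nM in this assay, and the step of a 1.2-fold lower number from compound 1 to compound 2 (0.07 log units; within the scatter) lies within the scatter, so compound 2 sits alongside compound 1, the only other measured compound, with no separation between the two. Compound 3 `O=C(CN1CCN(c2ccc([N+](=O)[O-])cc2)CC1)Nc1ccc(C(=O)/C=C/c2cn(Cc3ccc(Br)cc3)nn2)cc1` differs from compound 2 by 4-nitrophenyl in place of tert-butoxycarbonyl on an amine nitrogen in a ring. Among the compounds with values here, the only step that bears on this change, a 1.2-fold lower number from compound 1 to compound 2 (0.07 log units; within the scatter), exchanged 2-methoxyphenyl for tert-butoxycarbonyl on an amine nitrogen in a ring and moved nothing beyond the scatter; the return to an aryl group on that nitrogen is expected to move the number little as well, a 1.1-fold higher number from compound 2 to compound 3 (0.03 log units; within the scatter). Compound 3 is therefore estimated at 33000 nM, with a range of 15000 nM to 75000 nM.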

Compound 3, half-maximal inhibitory concentration: 31600 nM
Compound 3: middle estimate off by 1.0-fold (0.02 log units), on the high side; the range from low to high includes it.
By their numbers in this assay, from the lowest: compounds 2, 3 and 1 (each within the scatter of the next).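

At the amine nitrogen in the ring, 4-nitrophenyl shows no separation in this assay from tert-butoxycarbonyl (a 1.0-fold higher number from compound 2 to compound 3 (0.01 log units; within the scatter)) or from 2-methoxyphenyl (a 1.2-fold lower number from compound 1 to compound 3 (0.07 log units; within the scatter)). A second aryl group with a different substituent therefore gives no separation here, and all three groups, with or without a ring, lie within the scatter of one another. No measurement on hand offers an explanation for this. Still open, on these data alone, is whether the free ring amine, or a carboxylic acid on a longer chain at that nitrogen, would separate from these three groups.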